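Oxetanyl to allyl on the amide nitrogen of compound 1

The source may report more compounds than this note shows. Statements on the series, on what has been measured and on what is new or still open speak of the compounds shown alone.

Three compounds have numbers in an assay on HEK293 cells for agonist activity at transient receptor potential cation channel subfamily M member 8 (Homo sapiens), read by fluorescence and calcium flux, with a stated time of 15 min; a lower number here means that less compound is needed, a higher number that more compound is needed for the effect. Compound 1 `Cc1ccc(OCC(=O)N(Cc2cccs2)C2COC2)cc1` gives 23000 nM, the highest of the three. Compound 2 `CCN(Cc1cccs1)C(=O)c1cc2cc(C)ccc2o1`, built on a different core, gives 120 nM, and compound 3 `COc1ccc2oc(C(=O)N(Cc3cccs3)c3ccn[nH]3)cc2c1`, on a related core, gives 1.1 nM; both gaps to compound 1 lie beyond the scatter. The untested compound 4 `C=CCN(Cc1cccs1)C(=O)COc1ccc(C)cc1` keeps the core of compound 1 and changes one place: allyl in place of oxetan-3-yl on an amide-type nitrogen. Within the data shown here, no measured pair shows this change, so its size is a guess. The nitrogen of compound 2 also carries an open chain, and the low number for compound 2 of 120 nM hints that an open chain is tolerated, though its core differs. A moderate drop in number is expected, a 3.8-fold lower number from compound 1 to compound 4 (0.58 log units; beyond the scatter). Compound 4 is estimated at 6000 nM, within 1200 nM to 30000 nM.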

Compound 4, half-maximal effective concentration: 20 nM
For compound 4 the middle estimate is 300-fold (2.48 log units) above the measured one; measured number outside the range, below it.
By their numbers in this assay, from the lowest: compound 3; then compound 4; then compound 2; then compound 1.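

In this assay, this position on the amide-type nitrogen proves highly sensitive on the core of compound 1: allyl in place of oxetan-3-yl produces a large step beyond the scatter (a 1200-fold lower number from compound 1 to compound 4 (3.06 log units; beyond the scatter)). The change removes the four-membered ring, with its oxygen and hydrogen-bond acceptor, and brings in an open chain with a double bond. Nothing measured explains the step.

Propyl, lacking the double bond, would test whether that bond matters. A cyclobutyl group would test whether the ring oxygen or the ring as a whole matters.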